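The source may hold more compounds than are shown below. What is called first, only, known or untested is meant among the compounds shown, and "the series" means these compounds.

Compound 1 `CC(C)Cn1c(CN2CCN(C(=O)C3CC3)CC2)nc2ccccc21` gives 13.1% in an assay on isolated protein for inhibition of aldehyde dehydrogenase 1A1 (Homo sapiens), read by spectrophotometry, tested at 10 uM; a higher number here means more inhibition at the concentration tested (going by the name of the read-out), a lower number less inhibition. Compound 2 `Cc1ccccc1Cn1c(CN2CCN(C(=O)C3CC3)CC2)nc2ccccc21` gives 29.1%. Compound 3 `O=C(C1CC1)N1CCN(Cc2nc3ccccc3n2Cc2ccccc2F)CC1` gives 40.7%.

Compound 3 stands highest of the three: a number 11.6 percentage points higher from compound 2 to compound 3 (beyond the scatter) and a number 27.6 percentage points higher from compound 1 to compound 3 (beyond the scatter). Compound 4 `Cc1ccc(Cn2c(CN3CCN(C(=O)C4CC4)CC3)nc3ccccc32)cc1` is not yet measured; it differs from compound 3 in one place: 4-methylphenyl in place of 2-fluorophenyl on a saturated chain carbon bound to an aromatic nitrogen. Going by the values given here, the step that bears most directly is the exchange of fluoro and methyl on an aromatic carbon, a number 11.6 percentage points higher from compound 2 to compound 3 (beyond the scatter), modest in size; compound 4 runs it the other way, though as 4-methylphenyl rather than 2-methylphenyl, a placement no measured compound covers. Also, a number 16 percentage points higher from compound 1 to compound 2 (beyond the scatter) shows a methylphenyl already sits above compound 1. A modest fall is therefore expected, a number 12.7 percentage points lower from compound 3 to compound 4 (beyond the scatter). Compound 4 is estimated at 28%, within 12% to 44%.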

Compound 4, a percentage reported as inhibition, at one concentration (the size of the read-out at that concentration, not a potency): 51.5%
Compound 4: middle estimate off by 23.5 percentage points, on the low side; the measured number lies above the stated range.
By their numbers in this assay, from the lowest: compound 1; then compound 2; then compound 3; then compound 4.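

Moving the methyl around the ring matters at this position: in this assay, 4-methylphenyl in place of 2-methylphenyl gives a clear rise (a number 22.4 percentage points higher from compound 2 to compound 4 (beyond the scatter)). The 4-methylphenyl group also surpasses 2-fluorophenyl (a number 10.8 percentage points higher from compound 3 to compound 4 (beyond the scatter)) and isopropyl (a number 38.4 percentage points higher from compound 1 to compound 4 (beyond the scatter)), so the fluoro-over-methyl order seen with compound 2 and compound 3 does not extend to every methylphenyl. Nothing shown explains these differences. From the compounds shown here alone, whether fluoro at the placement of that methyl would keep the number remains open, as does what a plain phenyl or a pyridine ring would give.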